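Changing the aryl group on the triazole nitrogen

This account rests on a few compounds, and the source may have more. Where it says the series, first, only, none or still open, it means among the compounds named here.

Compound 1 `COc1cccc(-n2cc(COc3c(/C=C\C(=O)O)ccc(OC)c3CC=C(C)C)nn2)c1`: 20400 nM
Compound 2 `COc1ccc(/C=C\C(=O)O)c(OCc2cn(-c3nc4ccccc4s3)nn2)c1CC=C(C)C`: 17200 nM

Two compounds share a core and differ only in the group on the triazole nitrogen. In a functional assay on T47D cells (Homo sapiens) for cytotoxicity, read by MTT assay, with a stated time of 24 h (a lower number here means a stronger inhibitor, a higher number a weaker inhibitor), compound 1 gives 20400 nM, while compound 2 gives 17200 nM. The step of a 1.2-fold lower number from compound 1 to compound 2 (0.07 log units; within the scatter) is within the scatter, so compound 2 stands alongside compound 1 rather than apart from it.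

Compound 3 `COc1ccc(/C=C\C(=O)O)c(OCc2cn(-c3ccccc3C#N)nn2)c1CC=C(C)C` is not yet measured. It differs from compound 2 by 2-cyanophenyl in place of 1,3-benzothiazol-2-yl on an aromatic nitrogen. Among the compounds with values here, the only step that bears on this change is a 1.2-fold lower number from compound 1 to compound 2 (0.07 log units; within the scatter), where one aryl group on the same nitrogen replaced another without a change beyond the scatter. On that basis no step beyond the scatter is expected in this assay for compound 3 either.

Compound 3 is therefore estimated at 19000 nM, with a range from 8000 nM to 45000 nM, a step of a 1.1-fold higher number from compound 2 to compound 3 (0.04 log units; within the scatter) expected from compound 2.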

Compound 3, half-maximal inhibitory concentration: 8800 nM
Compound 3: middle estimate off by 2.2-fold (0.33 log units), on the high side, and the stated range covers the measured number.
By their numbers in this assay, from the lowest: compounds 3, 2 and 1 (each within the scatter of the next, the first and the last beyond it).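

In this assay, within the data shown here, the group on the triazole nitrogen now gives a first step beyond the scatter, a 2.3-fold lower number from compound 1 to compound 3 (0.37 log units; beyond the scatter) with 2-cyanophenyl in place of 3-methoxyphenyl, though that step is modest. The step against the other aryl group, a 2.0-fold lower number from compound 2 to compound 3 (0.29 log units; within the scatter) with 2-cyanophenyl in place of 1,3-benzothiazol-2-yl, stays within the scatter, so compound 3 stands apart from compound 1 but not from compound 2. Nothing measured here accounts for this small difference among the aryl groups.

The compounds shown leave open whether the nitrile itself matters, since an unsubstituted phenyl does not appear among them. They also leave open how this position would respond to something other than an aryl group, such as a short alkyl chain or an amine.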